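Lengthening the chain of an aminoanilide by one carbon

The source may hold more compounds than are shown below. What is called first, only, known or untested is meant among the compounds shown, and "the series" means these compounds.

Compound 1 `Cn1cc(-c2ccccc2Oc2ccccc2)c2cc(C(=O)NCCCCCC(=O)Nc3ccccc3N)[nH]c2c1=O` ends its chain in an (2-aminophenyl)carbamoyl group. In an assay on isolated protein for inhibition of protein deacetylase HDAC6 (Homo sapiens), read by fluorescence (on this read-out higher numbers stand for weaker inhibition and lower numbers for stronger inhibition), compound 1 returns only a limit, > 500 nM. Two other compounds in the set carry hydroxamic acid ends instead: compound 2 `CC(C)Oc1ccc(C(C)(C)O)cc1-c1cn(C)c(=O)c2[nH]c(C(=O)NCCCCCCC(=O)NO)cc12` gives 5.4 nM in this assay, and compound 3 `O=C(CCCCCCC(=O)Nc1cnc(N(c2ccccc2)c2ccccc2)nc1)NO` gives 4.4 nM. Compounds 2 and 3 lie within the scatter of each other, and compound 1 stands apart from both at the limit of > 500 nM in this assay, at which 1 of the 3 values shown sits, the one entry that is a limit rather than a number.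

Compound 4 `Cn1cc(-c2ccccc2Oc2ccccc2)c2cc(C(=O)NCCCCCCC(=O)Nc3ccccc3N)[nH]c2c1=O` differs from compound 1 in a single place: ((2-aminophenyl)carbamoyl)methyl in place of (2-aminophenyl)carbamoyl on a saturated chain carbon, five bonds along the chain from an amide-type nitrogen. For the measured compounds named here, no measured pair shares this change, so there is no measured step to lean on. The writer expects the step that the limit leaves unreadable from compound 1 to compound 4 to be small, and not to carry compound 4 beyond the scatter of where compound 1 sits. Compound 4 is therefore expected to give about 2000 nM in this assay, between 400 nM and 10000 nM, and quite possibly only a limit again.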

Compound 4, half-maximal inhibitory concentration: > 500 nM
Compound 4: only a limit was reported (the forecaster's own chance of this, stated with the estimate: 70%); the middle value lies beyond the limit too.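

Compound 1 and compound 4 both return only a limit in this assay, so no step between them can be read: the limit of > 500 nM in this assay, at which 2 of the 4 values shown sit.

The compounds shown leave open how large the effect of ((2-aminophenyl)carbamoyl)methyl in place of (2-aminophenyl)carbamoyl is, and in which direction it runs.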